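Swapping a fused bicyclic arm for a fluorinated benzyl group

A few compounds are considered here, and "the series" means these few. Any claim that something is new, unique, unknown or untested is made for them only; others in the source may bear on it.

Compound 3 `CNC(=O)c1cc(C(=O)NC2CC2)cn(Cc2nccc3[nH]ccc23)c1=O` gives 1.7 in a physicochemical assay for lipophilicity, at pH 7.4 (a lower number here means a more polar compound, a higher number a more lipophilic compound), the lowest of the three values here. Compound 1 `CNC(=O)c1cc(C(=O)NC2CCC2)cn(Cc2ccccn2)c1=O` gives 2.2 in this assay, a step beyond the scatter above compound 3, and compound 2 `CNC(=O)c1cc(C(=O)NCC(C)C)cn(Cc2ccccc2)c1=O` gives 4.3 in this assay, far above both. Compound 4 `CNC(=O)c1cc(C(=O)NC2CC2)cn(Cc2ccccc2F)c1=O` has not been measured. It differs from compound 3 in one place: a group of 7 heavy atoms (6 carbon, 1 fluorine; one six-membered aromatic ring of carbon only) in place of a group of 9 heavy atoms (7 carbon, 2 nitrogen; one five-membered aromatic ring with 1 hetero atom, one six-membered aromatic ring with 1 hetero atom), on a saturated chain carbon bound to an aromatic nitrogen. Among the measured compounds shown here, no step between measured compounds matches this change. Even so, the entering group is close to the benzyl arm of compound 2, whose reading of 4.3 in this assay is the highest seen, so an upward step well beyond the scatter is expected, estimated as a number 1.50 log units higher from compound 3 to compound 4 (beyond the scatter). Compound 4 is therefore expected to give about 3.2 in this assay, within 2.5 to 3.9.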

Compound 4, distribution coefficient: 3
For compound 4 the middle estimate is 0.20 log units above the measured one; measured number inside the range.
By their numbers in this assay, from the lowest: compound 3; then compound 1; then compound 4; then compound 2.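

With the rest of the molecule unchanged, this assay reads a number 1.30 log units higher from compound 3 to compound 4 (beyond the scatter) when 2-fluorophenyl replaces the fused group of two aromatic rings. Among the compounds shown here, this is the first comparison here that differs in one place, and it shows that this arm alone can produce a large change in the read-out. The compounds shown leave open how a phenyl ring carrying an amine or a carboxylic acid would read at this place. No supporting data show which part of the exchange accounts for the step.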